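The source may report more compounds than this note shows. Statements on the series, on what has been measured and on what is new or still open speak of the compounds shown alone.

In an ADME assay on microsomes from liver (Rattus norvegicus) for metabolic stability, with a stated time of 60 min, tested at 1 uM (a higher number here means that more of the compound is left, a lower number that less of the compound is left), compound 2 (`COc1cc(-c2cnn3cc(OC)c(-c4cc(C)no4)nc23)ccn1`) stands lowest of the two measured compounds at 62%, while compound 1 (`CNc1nc2c(-c3ccnc(OC)c3)cnn2cc1OC`) gives 74%. The next compound, compound 3 (`COc1cc(-c2cnn3cc(OC)c(C(C)(C)O)nc23)ccn1`), keeps the shared core but carries 1-hydroxy-1-methylethyl in place of 3-methyl-1,2-oxazol-5-yl on an aromatic carbon. Among the compounds with values here, only one measured step bears on this change, the modest a number 12 percentage points lower from compound 1 to compound 2 (beyond the scatter), which brought in the group that now leaves. Within the data shown here, the group that enters has no measured precedent, so that step is only a loose guide. It points to a small recovery rather than a full return, and no step beyond the scatter is expected in this assay. The expected change is a number 6 percentage points higher from compound 2 to compound 3 (within the scatter), a slight rise at most. Compound 3 is estimated at 68%, with an expected range of 50% to 84%.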

Compound 3, percent of the compound remaining: 92%
Beside the measured number, compound 3's estimate is 24 percentage points below it, outside the stated range (above it).
By their numbers in this assay, from the lowest: compound 2; then compound 1; then compound 3.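

In this assay the earlier compounds had shown this position, on an aromatic carbon next to the ring nitrogen, only as a place where the read-out fell; 1-hydroxy-1-methylethyl in place of 3-methyl-1,2-oxazol-5-yl now shows that it can also rise sharply (a number 30 percentage points higher from compound 2 to compound 3 (beyond the scatter)). The entering group also surpasses methylamino (a number 18 percentage points higher from compound 1 to compound 3 (beyond the scatter)), so this change does more than recover what was lost with 3-methyl-1,2-oxazol-5-yl. Of the three groups seen here, 1-hydroxy-1-methylethyl, the only one carrying a hydroxyl, leaves the most compound.

Nothing available bears on why the read-out rises with this group. On these data alone, whether hydroxymethyl, a primary amine or a carboxylic acid at this place would give a similar read-out remains open.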